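A few compounds are considered here, and "the series" means these few. Any claim that something is new, unique, unknown or untested is made for them only; others in the source may bear on it.

The three measured compounds, all in a toxicity assay on Vero cells (Chlorocebus sabaeus) for cytotoxicity; a lower number here means that less compound is tolerated, a higher number that more compound is tolerated:
Compound 1 `COc1nc(-c2ccc(C#N)cc2)ccc1[C@@H](c1ccccc1)[C@@](O)(CCN(C)C)c1cccc2ccccc12` gives only a limit, > 50 ug/mL.
Compound 2 `COc1nc(-c2ccc(Cl)cc2)ccc1[C@@H](c1ccccc1)[C@@](O)(CCN(C)C)c1cccc2ccccc12` gives only a limit, > 50 ug/mL.
Compound 3 `COc1nc(-c2cccc(Cl)c2)ccc1[C@@H](c1ccccc1)[C@@](O)(CCN(C)C)c1cccc2ccccc12` gives only a limit, > 50 ug/mL.

Compound 1 therefore stands at the limit of this assay rather than at a number, and so do the other two, as the limit of > 50 ug/mL in this assay, at which 3 of the 3 values shown sit, shows. None of the three yields a number, so the steps among them cannot be read in size: a step that the two limits leave unreadable from compound 1 to compound 2, a step that the two limits leave unreadable from compound 1 to compound 3 and a step that the two limits leave unreadable from compound 2 to compound 3. All that can be said is that each of these changes kept the compound at the limit.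

Compound 4 `COc1nc(C2CCCCC2)ccc1[C@@H](c1ccccc1)[C@@](O)(CCN(C)C)c1cccc2ccccc12` has not been measured. It differs from compound 1 in one place: cyclohexyl in place of 4-cyanophenyl on an aromatic carbon. The measured steps that bear on this change are the two in which the same group on compound 1 is exchanged, a step that the two limits leave unreadable from compound 1 to compound 2 and a step that the two limits leave unreadable from compound 1 to compound 3; both are unreadable, and neither brings in a cyclohexyl, so they only show that the limit was reached each time. In this assay no step beyond the scatter is therefore expected from compound 1 to compound 4, in either direction, and the step is expected to be a step that the limit leaves unreadable from compound 1 to compound 4. Compound 4 is expected to give 60 ug/mL, in a range from 30 ug/mL to 120 ug/mL, most likely again as a limit.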

Compound 4, half-maximal cytotoxic concentration: 32.3 ug/mL
For compound 4 the middle estimate is 1.9-fold (0.27 log units) above the measured one, and the stated range covers the measured number.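

In this assay, compound 4 is the only one of the four compounds shown that gives a number rather than a limit, so a change at this aromatic carbon next to the ring nitrogen can bring the read-out into the measurable range. Placing cyclohexyl there gives an at least 1.5-fold lower number from compound 1 to compound 4 (0.18 log units; that floor lies within the scatter), an at least 1.5-fold lower number from compound 2 to compound 4 (0.18 log units; that floor lies within the scatter) and an at least 1.5-fold lower number from compound 3 to compound 4 (0.18 log units; that floor lies within the scatter). Each of these is only a floor, so none establishes a real drop, and the steps among compound 1, compound 2 and compound 3 remain unreadable, with all their values sitting at one limit: the limit of > 50 ug/mL in this assay, at which 3 of the 4 values shown sit.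

From the compounds shown here alone, it remains open whether the non-aromatic ring itself matters at this position, a question that an unsubstituted phenyl, a piperidine or a longer alkyl chain in the same place could help to answer. Also open, going by these compounds, is how far the true values of compound 1, compound 2 and compound 3 lie beyond their limit, so the full size of each step to compound 4 is unknown.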